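This account rests on a few compounds, and the source may have more. Where it says the series, first, only, none or still open, it means among the compounds named here.

Compound 1 `Nc1scc(CN2CCN(c3ccc(F)c(Cl)c3)CC2)c1C(=O)c1ccc(Cl)cc1` gives -60% in a functional assay on CHO cells with adenosine receptor A1 (Homo sapiens) as the target, read by cAMP accumulation and immunoassay, with a stated time of 6 min, tested at 1 uM; on this read-out lower numbers stand for a stronger effect and higher numbers for a weaker effect at the one concentration tested. Compound 2 `Nc1scc(CN2CCN(c3ccccc3Cl)CC2)c1C(=O)c1ccc(Cl)cc1` gives -5.2% in this assay.

Compound 2 stands highest of the two numbers; its nearest neighbour is compound 1, with a number 54.8 percentage points higher from compound 1 to compound 2 (beyond the scatter). Compound 3 `Nc1scc(CN2CCN(c3ccc(Cl)c(Cl)c3)CC2)c1C(=O)c1ccc(Cl)cc1` is not yet measured. It differs from compound 2 by 3,4-dichlorophenyl in place of 2-chlorophenyl on an amine nitrogen in a ring. Among the measured compounds shown here, the one measured step that bears on this change is a number 54.8 percentage points higher from compound 1 to compound 2 (beyond the scatter), a large step beyond the scatter. Since 3,4-dichlorophenyl is closer in pattern to the 3-chloro-4-fluorophenyl of compound 1 than to the 2-chlorophenyl of compound 2, a downward step beyond the scatter is expected in this assay, namely a number 44.8 percentage points lower from compound 2 to compound 3 (beyond the scatter). Compound 3 is therefore estimated at -50%, expected between -75% and -20%.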

Compound 3, a percentage reported as activity, at one concentration (the size of the read-out at that concentration, not a potency): -60%
The estimate for compound 3 lay 10 percentage points above the measured number; the range from low to high includes it.
By their numbers in this assay, from the lowest: compounds 1 and 3 (each within the scatter of the next); then compound 2.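

With 3,4-dichlorophenyl in place of 2-chlorophenyl, this assay gives a number 54.8 percentage points lower from compound 2 to compound 3 (beyond the scatter) and so shows that the large step seen earlier is not unique to the 3-chloro-4-fluorophenyl group. Chloro in place of fluoro on the aromatic carbon gives no change at the digits printed from compound 1 to compound 3 (within the scatter) and so, at this one concentration, the two halogens cannot be told apart at that place. Nothing available explains either result. Still open, on these data alone, is how an unsubstituted phenyl, or a phenyl carrying methoxy or trifluoromethyl in place of these halogens, would read out in this assay.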